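This account rests on a few compounds, and the source may have more. Where it says the series, first, only, none or still open, it means among the compounds named here.

Compound 1, `COc1cccc(S(=O)(=O)/C=C/c2ccccn2)c1`, in an ADME assay on BV-2 cells (Mus musculus) for cytotoxicity, with a stated time of 24 h, tested at 50 uM; a higher number here means a weaker effect of the compound at the concentration tested, a lower number a stronger effect: 98.9%. Compound 2, `COc1cccc(S(=O)(=O)/C=C/c2ncccc2F)c1`, in this assay: 97.4%. Compound 3, `COc1ccc(S(=O)(=O)/C=C/c2cccnc2)cc1`, in this assay: 85.8%.

Compound 2 arises from compound 1 by the change (fluoro in place of hydrogen on an aromatic carbon), and this brought a number 1.5 percentage points lower from compound 1 to compound 2 (within the scatter). Compound 3 shares its atoms with compound 1 but joins them differently; the difference between the two cores is not broken down here. Its number in this assay is the lowest of the three, beyond the scatter from both compound 1 and compound 2.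

Compound 4, `COc1ccc(S(=O)(=O)/C=C/c2ccc(F)nc2)cc1`, has not yet been measured. It arises from compound 3 by fluoro in place of hydrogen on an aromatic carbon. This is the same kind of change as that from compound 1 to compound 2, not the same: there the fluoro sat ortho to a large group and two atoms from the ring nitrogen, here it sits next to the ring nitrogen and para to a large group. Because the earlier step was a number 1.5 percentage points lower from compound 1 to compound 2 (within the scatter), an expected step of a number 1.8 percentage points lower from compound 3 to compound 4 (within the scatter) in this assay is assumed. Compound 4 is therefore expected to give about 84%, between 70% and 97%.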

Compound 4, a percentage reported as activity, at one concentration (the size of the read-out at that concentration, not a potency): 95.7%
Beside the measured number, compound 4's estimate is 11.7 percentage points below it; measured number inside the range.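

In this assay, fluoro in place of hydrogen on an aromatic carbon gave a number 9.9 percentage points higher from compound 3 to compound 4 (within the scatter), so this step, like the earlier one, stays within the usual scatter of the measurement. Set side by side, the two steps cannot be told apart: the same change on two cores in this assay, a number 1.5 percentage points lower (within the scatter) from compound 1 to compound 2 and a number 9.9 percentage points higher (within the scatter) from compound 3 to compound 4, 11.4 percentage points apart, within the scatter of two such steps. Across these two cores, then, the change shows no difference in its step that stands out from the scatter, but this does not show that its step is the same on both, as the fluoro does not sit in the same place in the two pairs, and two pairs give no rule for the series.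

The compounds shown leave open whether a chloro group, an amine or a carboxylic acid on the same aromatic carbon would give a step of similar size in this assay. They also leave open whether the fluoro step would stay within the scatter on a third core.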